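A few compounds are considered here, and "the series" means these few. Any claim that something is new, unique, unknown or untested is made for them only; others in the source may bear on it.

Measured compounds:
compound 1, `Cc1cccc(-c2nc3cc(C)ccc3c(=O)[nH]2)c1`: 100%
compound 2, `Cc1ccc2c(=O)[nH]c(-c3ccccc3C)nc2c1`: 100%

In an assay on isolated protein for inhibition of DNA topoisomerase 1 (Homo sapiens), with a stated time of 30 min, tested at 100 uM (a higher number here means a stronger effect of the compound at the concentration tested, a lower number a weaker effect), compound 1 gives 100%. In the same assay compound 2 gives 100%. Compound 2 thus stands level with compound 1 at the digits shown, the nearest measured compound, with no change beyond the scatter.

Compound 3, `Cc1ccc2c(=O)[nH]c(-c3ccccc3F)nc2c1`, is not yet measured in this assay. It differs from compound 2 by fluoro in place of methyl on an aromatic carbon. For the measured compounds named here, no step between measured compounds covers this change, so the expected step of a number 4 percentage points lower from compound 2 to compound 3 (within the scatter) is none beyond the scatter, given that compound 2 reads 100%. Compound 3 is estimated at 96%, expected range 78% to 100%.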

Compound 3, a percentage reported as inhibition, at one concentration (the size of the read-out at that concentration, not a potency): 81.2%
Compound 3: middle estimate off by 14.8 percentage points, on the high side; measured number inside the range.
By their numbers in this assay, from the lowest: compound 3; then compounds 1 and 2 (each within the scatter of the next).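

In this assay, fluoro in place of methyl on this aromatic carbon, ortho to a large group, gives a number 18.8 percentage points lower from compound 2 to compound 3 (beyond the scatter), so the read-out does respond to the group held here. The change lowers the read-out without removing it, as compound 3 still gives 81.2%. Nothing available bears on the reason for this step.

Still open, going by these compounds, is how chloro, methoxy or an amine on this same carbon would read. Also open, on these data alone, is whether fluoro elsewhere on this ring would give a similar step.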